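Adding a Methoxy Group to a Compound at the Limit

This account rests on a few compounds, and the source may have more. Where it says the series, first, only, none or still open, it means among the compounds named here.

In a functional assay on MDA-MB-231 cells (Homo sapiens), read by microscopy and transwell migration, with a stated time of 24 h (a higher number here means a weaker inhibitor, a lower number a stronger inhibitor), compound 1 (`CCn1c(-c2ccc(C)cc2C)cs/c1=N\C(=O)c1ccccc1`) gives a half-maximal inhibitory concentration of 1950 nM as a measured number. In this assay the result for compound 2 (`COc1ccc(C(=O)Nc2nc(-c3cc(OC)c(OC)c(OC)c3)cs2)cc1`) is > 25000 nM and this is a limit of the assay, not a number. Compound 3 (`COc1ccc(C(=O)Nc2nc(-c3cc(OC)c(OC)c(OC)c3)cs2)cc1OC`) differs from compound 2 in one place: methoxy in place of hydrogen on an aromatic carbon, ortho to a methoxy group, which turns 4-methoxyphenyl into 3,4-dimethoxyphenyl (methoxy in place of hydrogen on an aromatic carbon). Among the measured compounds shown here, no two measured compounds differ in just one place, so nothing measured yet shows what such a change does in this assay and any forecast is uncertain. The expectation is a small step towards stronger inhibition, possibly none beyond the scatter, and compound 3 may well return only a limit too. The estimate for compound 3 is 15000 nM as the expected value, with 3000 nM to 40000 nM as its expected range if a number is obtained. This estimate means an at least 1.6-fold lower number from compound 2 to compound 3 (0.22 log units; that floor lies within the scatter) as the expected step, a modest one.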

Compound 3, half-maximal inhibitory concentration: > 25000 nM
Compound 3: a limit, no number; the forecaster's own chance of this, stated with the estimate: 55%; middle value at least 1.6-fold (0.22 log units) away from the limit.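

In this assay compound 3 gives > 25000 nM, which is a limit of the assay and not a number. Compound 2 stands at the same limit, so no step from compound 2 to compound 3 can be read: the limit of > 25000 nM in this assay, at which 2 of the 3 values shown sit.

The compounds shown leave open whether turning 4-methoxyphenyl into 3,4-dimethoxyphenyl changes inhibition at all.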